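Moving trifluoromethyl: 4-(trifluoromethyl)phenyl to 2-(trifluoromethyl)phenyl

A few compounds are considered here, and "the series" means these few. Any claim that something is new, unique, unknown or untested is made for them only; others in the source may bear on it.

In a functional assay on HL-60 cells (Homo sapiens) for antiproliferative activity, read by MTT assay, with a stated time of 72 h (a lower number here means a stronger inhibitor, a higher number a weaker inhibitor), compound 1 `CCn1cc(C(=O)O)c(=O)c2cc(F)c(N3CCN(C(=N)NS(=O)(=O)c4ccc(C(F)(F)F)cc4)CC3)cc21` gives 43 nM. Compound 2 `N=C(NS(=O)(=O)c1ccccc1)N1CCN(c2cc3c(cc2F)c(=O)c(C(=O)O)cn3C2CC2)CC1` gives 43 nM, and compound 3 `N=C(NS(=O)(=O)c1ccc(C(F)(F)F)cc1)N1CCN(c2cc3c(cc2F)c(=O)c(C(=O)O)cn3C2CC2)CC1` gives 43 nM, so all three stand level. Compound 4 `CCn1cc(C(=O)O)c(=O)c2cc(F)c(N3CCN(C(=N)NS(=O)(=O)c4ccccc4C(F)(F)F)CC3)cc21` keeps the core of compound 1 but carries 2-(trifluoromethyl)phenyl in place of 4-(trifluoromethyl)phenyl on a sulfonyl sulfur. Two measured steps offer guidance: no change at the digits printed from compound 1 to compound 3 (within the scatter) for cyclopropyl in place of ethyl on an aromatic nitrogen, and no change at the digits printed from compound 2 to compound 3 (within the scatter) for trifluoromethyl in place of hydrogen on an aromatic carbon. Within the data shown here, neither step tests the new arrangement, since no measured compound carries 2-(trifluoromethyl)phenyl. The expected change is a 1.2-fold higher number from compound 1 to compound 4 (0.07 log units; within the scatter), with no direction favoured and nothing beyond the scatter anticipated. Compound 4 is estimated at 50 nM, within an expected range of 20 nM to 130 nM.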

Compound 4, half-maximal inhibitory concentration: 43 nM
For compound 4 the middle estimate is 1.2-fold (0.07 log units) above the measured one; low and high end bracket the measured number.
By their numbers in this assay, from the lowest: compounds 1, 2, 3 and 4 (each within the scatter of the next).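

In this assay, the result is no change at the digits printed from compound 1 to compound 4 (within the scatter) for 2-(trifluoromethyl)phenyl in place of 4-(trifluoromethyl)phenyl on a sulfonyl sulfur. Among these compounds, the earlier steps only set trifluoromethyl against hydrogen, so this is the first reading of where on the phenyl ring the group stands, and here the two arrangements cannot be told apart. No measurement shown bears on this result.

From the compounds shown here alone, whether a nitrile or an amine in place of trifluoromethyl would give a similar number remains open. So does whether 2-(trifluoromethyl)phenyl behaves the same with cyclopropyl in place of ethyl on the aromatic nitrogen.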